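This account rests on a few compounds, and the source may have more. Where it says the series, first, only, none or still open, it means among the compounds named here.

Measured so far:
compound 1 `Cc1ccc(OCC(=O)N(Cc2cccs2)c2nccs2)cc1` — 2240 nM
compound 2 `CCN(Cc1cccs1)C(=O)COc1ccc2c(c1)COC2` — 61 nM

In an assay on HEK293 cells for agonist activity at transient receptor potential cation channel subfamily M member 8 (Homo sapiens), read by fluorescence and calcium flux, with a stated time of 15 min (on this read-out higher numbers stand for an effect only at larger amounts of compound and lower numbers for an effect already at smaller amounts), compound 1 gives 2240 nM, the highest of the two numbers, while compound 2 gives 61 nM, lower by a margin well beyond the scatter. Compound 3 `Cc1ccc(OCC(=O)N(Cc2cccs2)C2CC2)cc1` is not yet measured; it differs from compound 1 by cyclopropyl in place of 1,3-thiazol-2-yl on an amide-type nitrogen. Among the compounds with values here, no measured pair isolates this change, so its size is uncertain. The step expected here is a 4.5-fold lower number from compound 1 to compound 3 (0.65 log units; beyond the scatter), a drop in the number beyond the scatter. For compound 3 the estimate in this assay is 500 nM, with a range from 120 nM to 2000 nM.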

Compound 3, half-maximal effective concentration: 8 nM
For compound 3 the middle estimate is 63-fold (1.80 log units) above the measured one; the measured number lies below the stated range.
By their numbers in this assay, from the lowest: compound 3; then compound 2; then compound 1.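

In this assay, cyclopropyl in place of 1,3-thiazol-2-yl on the amide-type nitrogen gives a 280-fold lower number from compound 1 to compound 3 (2.45 log units; beyond the scatter). Within the data shown here, this is the first comparison that isolates this position, and it shows that the group on this nitrogen alone can shift the number by a large step. It also shows that the 1,3-thiazol-2-yl ring is not required for a low number on this core, though no evidence here accounts for the size of the step. The compounds shown leave open whether the step comes from gaining cyclopropyl or from losing 1,3-thiazol-2-yl, a question that a cyclobutyl or isopropyl group on the same nitrogen would bear on. From the compounds shown here alone, compound 2 differs from compound 3 in more than one place, so whether the change carries over to other cores also stays open.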